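Trifluoromethyl to 4-methoxyphenyl on the amide aryl group

This account rests on a few compounds, and the source may have more. Where it says the series, first, only, none or still open, it means among the compounds named here.

In a functional assay on CWR22R cells (Homo sapiens) for inhibition, read by sulforhodamine B assay, with a stated time of 72 h (a lower number here means a stronger inhibitor, a higher number a weaker inhibitor), compound 1 `COc1ccc(Cn2nnc(O)c2C(=O)Nc2cccc(C(F)(F)F)c2)cc1` gives 81400 nM and compound 2 `COc1ccc(Cn2nnc(O)c2C(=O)Nc2ccc(-c3ccccc3)cc2)cc1` gives 57900 nM, two numbers within the scatter of each other. The change of interest leads to compound 3 `COc1ccc(Cn2nnc(O)c2C(=O)Nc2cccc(-c3ccc(OC)cc3)c2)cc1`: 4-methoxyphenyl in place of trifluoromethyl on an aromatic carbon, with 4-methoxyphenyl in place of trifluoromethyl on an aromatic carbon. Within the data shown here, no measured step sizes this change, so no shift beyond the scatter is expected in this assay, with compound 2 at 57900 nM as the only guide. The estimated change is small, a 1.6-fold lower number from compound 1 to compound 3 (0.21 log units; within the scatter). Compound 3 is expected at 50000 nM, within a range of 20000 nM to 120000 nM.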

Compound 3, half-maximal inhibitory concentration: 50100 nM
Estimate against measurement, compound 3: 1.0-fold (0.00 log units) below; measured number inside the range.
By their numbers in this assay, from the lowest: compounds 3, 2 and 1 (each within the scatter of the next).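

In this assay, 4-methoxyphenyl in place of trifluoromethyl on an aromatic carbon, meta to a large group, gives a 1.6-fold lower number from compound 1 to compound 3 (0.21 log units; within the scatter). This position therefore takes the larger group, with its added aromatic ring, without a shift beyond the scatter, and the step does not separate the two groups. Nothing at hand offers an explanation for this flat result. Going by these compounds, whether an amine or a carboxylic acid at this position would move the number beyond the scatter remains open.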